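The source may hold more compounds than are shown below. What is called first, only, known or untested is meant among the compounds shown, and "the series" means these compounds.

Compound 2 `CC1(C)[C@@H]2CC[C@@]1(CS(=O)(=O)N1CCN(c3ncc(C(F)(F)F)cc3Cl)CC1)C(=O)C2` gives 398 nM in a functional assay on CHO-K1 cells for antagonist activity at C-X-C chemokine receptor type 3 (Homo sapiens), read by FLIPR and calcium flux (on this read-out higher numbers stand for weaker inhibition and lower numbers for stronger inhibition), the lowest of the two numbers in this set. Compound 1 `CC1(C)[C@@H]2CC[C@@]1(CS(=O)(=O)N1CCN(c3ncc(C(F)(F)F)cc3[N+](=O)[O-])CC1)C(=O)C2`, which differs from it at one aromatic carbon, gives 3160 nM, so that a 7.9-fold lower number from compound 1 to compound 2 (0.90 log units; beyond the scatter) counts as a modest step. Compound 3 `CN(CCN(C)S(=O)(=O)C[C@]12CC[C@H](CC1=O)C2(C)C)c1ccc(C(F)(F)F)cn1`, with a different linking chain, gives > 31600 nM, which is a limit of the assay rather than a number. That reading is the limit of > 31600 nM in this assay, at which 1 of the 3 values shown sits.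

Compound 4 `CC1(C)[C@@H]2CC[C@@]1(CS(=O)(=O)N1CCN(c3nc(Cl)c(C(F)(F)F)cc3Cl)CC1)C(=O)C2` has not been measured. It differs from compound 2 by chloro in place of hydrogen on an aromatic carbon, the new chloro sitting on the six-membered aromatic ring with one nitrogen, next to the ring nitrogen, ortho to the trifluoromethyl group and para to the chloro already present. Among the measured compounds shown here, no measured step adds a chloro in place of hydrogen anywhere in this set. For the measured compounds named here, the only measured step on the same ring is a 7.9-fold lower number from compound 1 to compound 2 (0.90 log units; beyond the scatter), and it concerns an exchange of nitro for chloro rather than the present change, so it gives no direction for the new substitution. Compound 4 is therefore expected to show only a 1.0-fold higher number from compound 2 to compound 4 (0.00 log units; within the scatter), a change not beyond the usual scatter. Compound 4 is estimated at 400 nM, within a range of 100 nM to 1600 nM.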

Compound 4, half-maximal inhibitory concentration: 316 nM
The estimate for compound 4 lay 1.3-fold (0.10 log units) above the measured number; the measured number falls inside the stated range.
By their numbers in this assay, from the lowest: compounds 4 and 2 (each within the scatter of the next); then compound 1. At a limit, above all of these: compound 3.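

In this assay, placing a chloro in place of hydrogen on this aromatic carbon, next to the ring nitrogen and ortho to a trifluoromethyl group, gives a 1.3-fold lower number from compound 2 to compound 4 (0.10 log units; within the scatter), so compound 2 and compound 4 cannot be told apart on this read-out. Among the compounds shown here, this is the first reading at this carbon, and it shows that the added chloro is accepted here without a change beyond the scatter, unlike the exchange of nitro for chloro elsewhere on the same ring, which gives a 7.9-fold lower number from compound 1 to compound 2 (0.90 log units; beyond the scatter). Nothing measured among these compounds explains why the new chloro leaves the number within the scatter.

Hydrogen and chloro are the only groups shown on this carbon, so it remains open whether a methyl, a methoxy group, an amine or a nitrile there would also leave the number within the scatter. Also open, going by these compounds, is whether the same chloro would be accepted alongside a different linking chain, as in compound 3, whose > 31600 nM is a limit of the assay and not a number.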